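Octylsulfanyl in Place of Octyloxy: An Untested Swap

The source may hold more compounds than are shown below. What is called first, only, known or untested is meant among the compounds shown, and "the series" means these compounds.

Three compounds have been measured in an assay on microsomes from intestine for inhibition of acyl-CoA:cholesterol acyltransferase (Oryctolagus cuniculus); on this read-out lower numbers stand for stronger inhibition and higher numbers for weaker inhibition:
Compound 1 `CC(C)c1cccc(C(C)C)c1OC(=O)NC(=O)OCCCc1ccccc1` gives 660 nM.
Compound 2 `CCCCCCCCOC(=O)NC(=O)Oc1c(C(C)C)cccc1C(C)C` gives 250 nM.
Compound 3 `CCCCCCCCCCCCCOC(=O)NC(=O)Oc1c(C(C)C)cccc1C(C)C` gives 9 nM.

Compound 2 stands second highest of these three numbers. Against compound 1 the change was a 2.6-fold lower number from compound 1 to compound 2 (0.42 log units; beyond the scatter); against compound 3 it was a 28-fold lower number from compound 2 to compound 3 (1.44 log units; beyond the scatter), and from compound 1 to compound 3 a 73-fold lower number from compound 1 to compound 3 (1.87 log units; beyond the scatter).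

Compound 4 `CCCCCCCCSC(=O)NC(=O)Oc1c(C(C)C)cccc1C(C)C` is the next candidate. It differs from compound 2 by octylsulfanyl in place of octyloxy on a carbonyl carbon. Within the data shown here, none of the measured steps bears on this place: each of them alters the chain beyond the oxygen, not the atom joined to the carbonyl carbon. With no guidance, the expected step in this assay from compound 2 to compound 4 is none beyond the scatter, no change at the digits printed from compound 2 to compound 4 (within the scatter). The estimate for compound 4 in this assay is therefore 250 nM, with a range from 80 nM to 800 nM.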

Compound 4, half-maximal inhibitory concentration: 160 nM
Compound 4: the middle estimate sits 1.6-fold (0.19 log units) above what was measured, and the stated range covers the measured number.
By their numbers in this assay, from the lowest: compound 3; then compounds 4 and 2 (each within the scatter of the next); then compound 1.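

Octylsulfanyl in place of octyloxy on a carbonyl carbon, a place no earlier step touched, gives a 1.6-fold lower number from compound 2 to compound 4 (0.19 log units; within the scatter) in this assay. With the octyl chain kept, the sulfur and oxygen versions therefore cannot be told apart on this read-out. No evidence is available to explain this result.

Still open, from the compounds shown here alone, is how octylamino, with a nitrogen joined to the carbonyl carbon, would compare at this place. Among these compounds, also open is whether a sulfur-linked longer chain, such as the one in compound 3, would track its oxygen-linked counterpart.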